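Nitro Substitution Carried From One Core to Another

The source may report more compounds than this note shows. Statements on the series, on what has been measured and on what is new or still open speak of the compounds shown alone.

Compound 1 `CCn1cc(-c2nc3ccccc3[nH]2)c(=O)c2cc(F)c(N3CCNCC3)nc21` and compound 2 `CCn1cc(-c2nc3ccccc3o2)c(=O)c2cc(F)c(Cl)cc21` share part of their structure, but the difference between the two cores is not broken down here. In a functional assay on Bel-7402 cells (Homo sapiens) for cytotoxicity, read by MTT assay, with a stated time of 48 h (a lower number here means a stronger inhibitor, a higher number a weaker inhibitor), compound 1 gives 4100 nM, while compound 2 gives 28900 nM, the highest number among the three measured compounds. Compound 3 `CCn1cc(-c2nc3ccc([N+](=O)[O-])cc3[nH]2)c(=O)c2cc(F)c(N3CCNCC3)nc21` carries the change (nitro in place of hydrogen on an aromatic carbon); in this assay compound 3 gives 10800 nM, a step of a 2.6-fold higher number from compound 1 to compound 3 (0.42 log units; beyond the scatter). Compound 4 `CCn1cc(-c2nc3ccc([N+](=O)[O-])cc3o2)c(=O)c2cc(F)c(Cl)cc21` carries the same change on the core of compound 2, (nitro in place of hydrogen on an aromatic carbon), at a place described in identical words. The expected step is a 2.4-fold higher number from compound 2 to compound 4 (0.38 log units; beyond the scatter), resting on the measured 2.6-fold higher number from compound 1 to compound 3 (0.42 log units; beyond the scatter), with wider uncertainty because compound 2 already gives 28900 nM. Compound 4 is therefore estimated at 70000 nM in this assay, expected between 25000 nM and 200000 nM.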

Compound 4, half-maximal inhibitory concentration: 1800 nM
Compound 4: the middle estimate sits 39-fold (1.59 log units) above what was measured; the whole stated range lies above it.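

In this assay nitro in place of hydrogen on an aromatic carbon gives a 16-fold lower number from compound 2 to compound 4 (1.21 log units; beyond the scatter) on the core of compound 2, against a step in the opposite direction on the core of compound 1, and the two steps disagree: the same change on two cores in this assay, a 2.6-fold higher number (0.42 log units; beyond the scatter) from compound 1 to compound 3 and a 16-fold lower number (1.21 log units; beyond the scatter) from compound 2 to compound 4, 42-fold (1.63 log units) apart, beyond the scatter of two such steps. In this series, then, the step measured on one core did not carry over to the other, in size or in direction. This does not show which difference between the two cores matters, and one pair on each core cannot show how general the reversal is.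

The compounds shown leave open whether an amine or a carboxylic acid on that aromatic carbon would also move in opposite directions on the two cores.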